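Thiophen-2-yl replaces 2-fluorophenyl on a shared core

The compounds below may be only part of what the source reports. "The series", "measured", "known", "first", "only" and "open" are said of these compounds alone.

Three measured compounds share one core and differ only in the aromatic group attached to it. In a functional assay on MOLT-4 cells (Homo sapiens) for inhibition, read by sulforhodamine B assay, with a stated time of 48 h, tested at 10 uM (a higher number here means more inhibition at the concentration tested (going by the name of the read-out), a lower number less inhibition), compound 1 `Clc1ccc(-c2cn3ccnc3c(-c3ccc4ncn(C5CCCCC5)c4c3)n2)cc1` gives 8.87%, compound 2 `COc1ccccc1-c1cn2ccnc2c(-c2ccc3ncn(C4CCCCC4)c3c2)n1` gives 22.4%, and compound 3 `Fc1ccccc1-c1cn2ccnc2c(-c2ccc3ncn(C4CCCCC4)c3c2)n1` gives 22.5%. Compound 3 shows the highest of the three numbers, but compound 2 sits within the scatter of it, and only the distance to compound 1 is beyond it. Compound 4 `c1csc(-c2cn3ccnc3c(-c3ccc4ncn(C5CCCCC5)c4c3)n2)c1` differs from compound 3 in one place: thiophen-2-yl in place of 2-fluorophenyl on an aromatic carbon. For the measured compounds named here, the steps that bear on this change are a number 13.5 percentage points higher from compound 1 to compound 2 (beyond the scatter), a number 13.6 percentage points higher from compound 1 to compound 3 (beyond the scatter) and a number 0.1 percentage points higher from compound 2 to compound 3 (within the scatter); the first two are modest, the third within the scatter. The step expected here, a number 5.5 percentage points lower from compound 3 to compound 4 (within the scatter), is therefore small and probably within the scatter. Compound 4 is estimated at 17%, between 4% and 32%.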

Compound 4, a percentage reported as inhibition, at one concentration (the size of the read-out at that concentration, not a potency): 30.8%
For compound 4 the middle estimate is 13.8 percentage points below the measured one; the range from low to high includes it.
By their numbers in this assay, from the lowest: compound 1; then compounds 2, 3 and 4 (each within the scatter of the next).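

In this assay, for the compounds shown here, a five-membered aromatic ring with one hetero atom now sits at this position, where the earlier compounds carried only six-membered aromatic rings of carbon. The thiophen-2-yl group stays within the scatter of both ortho-free comparisons that matter here: a number 8.3 percentage points higher from compound 3 to compound 4 (within the scatter) and a number 8.4 percentage points higher from compound 2 to compound 4 (within the scatter). Only a number 21.9 percentage points higher from compound 1 to compound 4 (beyond the scatter) lies beyond the scatter, so the 4-chlorophenyl compound remains the one separated from the others.

No measurement shown explains these numbers. As far as these compounds go, whether an amine or a carboxylic acid on this ring position would move the number beyond the scatter of compound 4 remains open.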